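From Chloro to Hydroxy: Expecting Compound 4

A few compounds are considered here, and "the series" means these few. Any claim that something is new, unique, unknown or untested is made for them only; others in the source may bear on it.

Of the compounds shown here, three sharing one core have been measured in a functional assay on the whole organism with Rattus norvegicus as the target, read by paw edema, with a stated time of 3 h, at a dose of 100 mg/kg by the oral route; on this read-out higher numbers stand for more inhibition at the one dose given (going by the name of the read-out) and lower numbers for less inhibition. Compound 1 `Cc1ccc(-c2nc3cc(Cl)ccc3[nH]2)nc1` gives -5%. Compound 2 `Cc1cccc(-c2nc3cc(Cl)ccc3[nH]2)n1` gives 39%. Compound 3 `CCc1ccc(-c2nc3cc(Cl)ccc3[nH]2)nc1` gives -2%. Among these three numbers compound 3 stands second highest. Going by the values given here, its nearest neighbour is compound 1, and the only measured step, a number 3 percentage points higher from compound 1 to compound 3 (within the scatter), is a methyl in place of hydrogen on a saturated chain carbon bound to an aromatic carbon that amounts to nothing beyond the scatter. Its furthest neighbour is compound 2, whose number sits beyond the scatter above that of compound 3.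

Compound 4 `CCc1ccc(-c2nc3cc(O)ccc3[nH]2)nc1` differs from compound 3 in a single place: hydroxy in place of chloro on an aromatic carbon. The chloro leaves and a hydroxy enters on the same aromatic carbon. No measured step touches a change of this kind; the one step shown concerns a saturated chain carbon elsewhere in the molecule and was flat. The numbers therefore point in neither direction, and the estimate rests on compound 3 alone. The step of a number 2 percentage points higher from compound 3 to compound 4 (within the scatter) is expected to stay within the scatter. For compound 4 the value expected in this assay is 0%, with a range from -15% to 20%.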

Compound 4, a percentage reported as inhibition, in the whole organism at one dose (the size of the read-out at that dose, not a potency): 25%
For compound 4 the middle estimate is 25 percentage points below the measured one, and the stated range ends below it.
By their numbers in this assay, from the lowest: compounds 1 and 3 (each within the scatter of the next); then compound 4; then compound 2.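

In this assay, a number 27 percentage points higher from compound 3 to compound 4 (beyond the scatter) shows that hydroxy in place of chloro on an aromatic carbon can move the number beyond the scatter, which the earlier single-place change, a number 3 percentage points higher from compound 1 to compound 3 (within the scatter), did not do at its saturated chain carbon. This position, on a six-membered aromatic ring of carbon only that is part of a fused or bridged system of two rings, is therefore one where a change of a single heavy atom goes with a clear difference, and the chloro with its 0 hydrogen-bond donors and 0 hydrogen-bond acceptors gives way to a hydroxy with 1 of each. The data offer no explanation for this step.

As far as these compounds go, whether a methoxy, an amine or a plain hydrogen on the same aromatic carbon would give a number like that of compound 4 remains open, so the step cannot yet be tied to the hydroxy itself rather than to the loss of the chloro. Also open, from the compounds shown here alone, is whether the same exchange would change the number of compound 2, which stands at 39% with the chloro in place.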